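The source may hold more compounds than are shown below. What is called first, only, known or untested is meant among the compounds shown, and "the series" means these compounds.

Of the compounds shown here, three have been measured in a functional assay on DU-145 cells (Homo sapiens) for inhibition, read by trypan blue exclusion, with a stated time of 96 h; on this read-out lower numbers stand for stronger inhibition of growth and higher numbers for weaker inhibition of growth. Compound 1 `Cc1ccsc1/C=C(/SCc1ccc(F)cc1)C(=O)c1ccc(Br)cc1` gives 50000 nM in this assay. Compound 2 `O=C(O)c1ccc(C(=O)/C(=C\c2ccc(Cl)c([N+](=O)[O-])c2)SCc2ccccc2F)cc1` gives 1000 nM in this assay, and compound 3 `O=C(/C(=C\c1ccccc1OCc1ccccc1)SCc1ccc(F)cc1)c1ccc(Cl)cc1` gives 1000 nM in this assay. Compound 2 and compound 3 sit level with each other within the scatter, and together they hold the lowest of the three numbers; compound 1 lies furthest from compound 2, its number being higher by a margin beyond the scatter. Compound 4 `O=C(O)c1ccc(C(=O)/C(=C\c2ccc(Cl)c([N+](=O)[O-])c2)SCc2ccc(Br)cc2)cc1` has not been measured. It differs from compound 2 in one place: 4-bromophenyl in place of 2-fluorophenyl on a saturated chain carbon bound to a sulfur. Among the compounds with values here, no measured pair shows this kind of change, so no step size can be read from the data. The expected step is no change at the digits printed from compound 2 to compound 4 (within the scatter), which is not expected to exceed the scatter. Compound 4 is estimated at 1000 nM, with a range from 400 nM to 3000 nM.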

Compound 4, concentration for 50% growth inhibition: 500 nM
The estimate for compound 4 lay 2.0-fold (0.30 log units) above the measured number; the measured number falls inside the stated range.
By their numbers in this assay, from the lowest: compounds 4, 2 and 3 (each within the scatter of the next); then compound 1.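

In this assay, putting 4-bromophenyl in place of 2-fluorophenyl on a saturated chain carbon bound to a sulfur gives a 2.0-fold lower number from compound 2 to compound 4 (0.30 log units; within the scatter). Within the data shown here, this is the first comparison in the set between compounds differing in one place, and it shows that this position can take this swap with no change beyond the scatter. No supporting measurement bears on why the two groups read alike.

The swap alters both the halogen and its ring position, and the compounds shown do not separate the two. On these data alone, how an amine on this phenyl ring, or a longer chain in place of the single carbon linking it to sulfur, would read remains open.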